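The compounds below may be only part of what the source reports. "The series", "measured", "known", "first", "only" and "open" are said of these compounds alone.

Of the compounds shown here, three built on a shared core have been measured in a physicochemical assay for solubility, in phosphate buffer, measured as kinetic solubility (a higher number here means a more soluble compound, a lower number a less soluble compound), so far. Compound 1 `CC(C)C(/C=C1\NC(=O)NC1=O)c1ccc(-c2ccc3cccc(F)c3c2)[nH]c1=O` gives 10700 nM and stands lowest of the three. Compound 2 `CCC(CC)C(/C=C1\OC(=O)NC1=O)c1ccc(-c2ccc3cccc(F)c3c2)[nH]c1=O` gives 33700 nM and compound 3 `CC(C)/C(=C1\C(=O)NC(=O)N1C)c1ccc(-c2ccc3cccc(F)c3c2)[nH]c1=O` gives 22500 nM and both lie higher than compound 1, beyond the usual scatter of repeat measurements.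

Compound 4 `CC(C)C(CC1NC(=O)NC1=O)c1ccc(-c2ccc3cccc(F)c3c2)[nH]c1=O` has not yet been measured. It differs from compound 1 in one place, on a saturated chain carbon bound to an aromatic carbon and a saturated chain carbon, and the change there is a group of 8 heavy atoms (4 carbon, 2 nitrogen, 2 oxygen; one five-membered non-aromatic ring with 2 hetero atoms) in place of a group of 8 heavy atoms (4 carbon, 2 nitrogen, 2 oxygen; one five-membered non-aromatic ring with 2 hetero atoms), on a saturated chain carbon bound to an aromatic carbon and a saturated chain carbon in full. The group that enters is (2,5-dioxoimidazolidin-4-yl)methyl, which has one double bond fewer outside aromatic rings than the group that leaves.

Within the data shown here, no two measured compounds differ in just one place, so the data show no direct example of this change. Among the measured compounds shown here, the only guide is the spread of the measured values, with compound 1 at 10700 nM at the low end and compound 3 at 22500 nM above it. A modest upward step in this assay is therefore expected, about the size of the usual scatter. The estimated step is a 2.1-fold higher number from compound 1 to compound 4 (0.31 log units; beyond the scatter) as a rough guide. For compound 4 the expected value is 22000 nM within an estimated range of 9000 nM to 55000 nM.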

Compound 4, solubility: 12300 nM
For compound 4 the middle estimate is 1.8-fold (0.25 log units) above the measured one; the measured number falls inside the stated range.
By their numbers in this assay, from the lowest: compounds 1, 4, 3 and 2 (each within the scatter of the next, the first and the last beyond it).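

Among these compounds, this is the first comparison in this assay between two compounds that differ in one place, on a saturated chain carbon bound to an aromatic carbon and a saturated chain carbon. There, (2,5-dioxoimidazolidin-4-yl)methyl enters with one double bond fewer outside aromatic rings than the group that leaves, while the counts of heavy atoms, hydrogen-bond donors and hydrogen-bond acceptors stay the same, and the result is a 1.1-fold higher number from compound 1 to compound 4 (0.06 log units; within the scatter) so this single pair shows no difference that repeat measurements could resolve. Nothing measured here gives a reason for this result.

The compounds shown leave open whether a different group in this place, such as an amine or a carboxylic acid, would give a step beyond the usual scatter. They also leave open whether losing the same double bond would give a similar result in compound 2 or compound 3, since neither differs from compound 1 or compound 4 in just one place.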